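A New Amide Cap on Compound 1

The source may hold more compounds than are shown below. What is called first, only, known or untested is meant among the compounds shown, and "the series" means these compounds.

Compound 1 `COc1ccc(Cn2c(CCc3c[nH]c4ccccc34)nnc2[C@H](NC(=O)C(C)(C)N)c2c[nH]c3ccccc23)c(OC)c1` is tested in a functional assay on CHO cells for antagonist activity at growth hormone secretagogue receptor type 1 (Homo sapiens) (a lower number here means a stronger inhibitor, a higher number a weaker inhibitor), where compound 1 gives 14 nM. Its companion compound 2 `COc1ccc(Cn2c(CCc3ccccc3)nnc2[C@H](NC(=O)C(C)(C)N)c2c[nH]c3ccccc23)c(OC)c1` gives 17 nM in this assay, so the two numbers lie within the scatter of each other; the step of a 1.2-fold higher number from compound 1 to compound 2 (0.08 log units; within the scatter) changes only the chain end. Compound 3 `COc1ccc(Cn2c(CCc3c[nH]c4ccccc34)nnc2[C@H](NC(=O)c2cnccn2)c2c[nH]c3ccccc23)c(OC)c1` differs from compound 1 at another place: pyrazin-2-yl in place of 1-amino-1-methylethyl on a carbonyl carbon. Among the measured compounds shown here, no measured step touches this amide cap, so nothing measured bears on it directly, and only a modest step is expected in this assay. For compound 3 the estimate is 30 nM, within 8 nM to 120 nM, meaning an expected step of a 2.1-fold higher number from compound 1 to compound 3 (0.33 log units; beyond the scatter).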

Compound 3, antagonist equilibrium constant: 97 nM
Compound 3: the middle estimate sits 3.2-fold (0.51 log units) below what was measured; the range from low to high includes it.
By their numbers in this assay, from the lowest: compounds 1 and 2 (each within the scatter of the next); then compound 3.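

The amide cap carries weight in this assay: pyrazin-2-yl in place of 1-amino-1-methylethyl on the carbonyl carbon gives a 6.9-fold higher number from compound 1 to compound 3 (0.84 log units; beyond the scatter), while the chain-end change gave a 1.2-fold higher number from compound 1 to compound 2 (0.08 log units; within the scatter). So this position responds to a change in a way the earlier pair did not show. Nothing available explains why this cap gives the weaker number.

This single step cannot separate losing the amine from gaining the aromatic ring. As far as these compounds go, how a phenyl cap or a 2-aminoethyl cap on the same carbonyl carbon would read remains open.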